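The compounds below may be only part of what the source reports. "The series", "measured", "known", "first", "only" and "open" are said of these compounds alone.

Three compounds on the shared core have a number in a functional assay on U-373MG ATCC cells (Homo sapiens) for inhibition, read by MTT assay, with a stated time of 72 h; on this read-out lower numbers stand for stronger inhibition and higher numbers for weaker inhibition. Compound 1 `CC1(C)CC(NC(=S)Nc2ccc(C#N)cc2)c2cc(Cl)ccc2O1` gives 10000 nM, compound 2 `CC1(C)CC(NC(=S)NCc2ccccc2)c2cc(Br)ccc2O1` gives 29000 nM, and compound 3 `CC1(C)CC(NC(=S)Nc2cccc(C#N)c2)c2cc(Br)ccc2O1` gives 6000 nM. Going by the values given here, on these numbers compound 3 stands lowest, yet its gap to compound 1 is within the scatter; only the step of a 4.8-fold lower number from compound 2 to compound 3 (0.68 log units; beyond the scatter) lies beyond it. Compound 4 `CC1(C)CC(NC(=S)Nc2ccc(C#N)cc2)c2cc(Br)ccc2O1` differs from compound 3 in one place: 4-cyanophenyl in place of 3-cyanophenyl on an amide-type nitrogen. Among the compounds with values here, no measured step swaps 3-cyanophenyl for 4-cyanophenyl alone; compound 1 carries 4-cyanophenyl but also a different halogen on the core, and its value sits within the scatter of compound 3. The expectation for compound 4 is a step of a 1.5-fold higher number from compound 3 to compound 4 (0.18 log units; within the scatter) that stays within the scatter. The estimate for compound 4 is 9000 nM, within 4000 nM to 20000 nM.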

Compound 4, half-maximal inhibitory concentration: 22000 nM
Compound 4: the middle estimate sits 2.4-fold (0.39 log units) below what was measured; measured number outside the range, above it.
By their numbers in this assay, from the lowest: compounds 3 and 1 (each within the scatter of the next); then compounds 4 and 2 (each within the scatter of the next).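

With 4-cyanophenyl in place of 3-cyanophenyl on the amide-type nitrogen, the series shows a 3.7-fold higher number from compound 3 to compound 4 (0.56 log units; beyond the scatter), so the two cyanophenyl groups are not interchangeable at this position. Going by these compounds alone, with 4-cyanophenyl held constant, bromo in place of chloro on the aromatic carbon gives the first single-change reading of the halogen: a 2.2-fold higher number from compound 1 to compound 4 (0.34 log units; beyond the scatter). Against benzyl, 4-cyanophenyl gives a 1.3-fold lower number from compound 2 to compound 4 (0.12 log units; within the scatter), so the step away from benzyl seen with 3-cyanophenyl does not carry over.

No evidence at hand accounts for these steps. Still open, on these data alone, is whether an amine or a carboxylic acid in place of the nitrile would show the same dependence on position.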